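Replacing the pyrrolidine ester of compound 1

The source may report more compounds than this note shows. Statements on the series, on what has been measured and on what is new or still open speak of the compounds shown alone.

Within the data shown here, in an ADME assay on HeLa cells (Homo sapiens) for cytotoxicity, read by MTT assay (a lower number here means a stronger inhibitor, a higher number a weaker inhibitor), compound 1 (`COC(=O)[C@@H]1CCCN1C(=O)CCC(=O)Oc1ccc(C[C@H]2C(=O)OC[C@@H]2Cc2ccc(OC)c(OC)c2)cc1OC`) gives 145000 nM, the lowest of only two numbers so far. Compound 2 (`COc1ccc(C[C@H]2COC(=O)[C@@H]2Cc2ccc(OCc3cn(Cc4ccc(Cl)cc4)nn3)c(OC)c2)cc1OC`) gives 242000 nM, which lies within the scatter of compound 1, so these two values do not separate.

Compound 3 (`COC(=O)CNC(=O)CCC(=O)Oc1ccc(C[C@H]2C(=O)OC[C@@H]2Cc2ccc(OC)c(OC)c2)cc1OC`) has ((methoxycarbonyl)methyl)amino in place of 2-(methoxycarbonyl)pyrrolidin-1-yl on a carbonyl carbon. Among the measured compounds shown here, no pair of measured compounds differs in one place, so the series offers no direct precedent for this change. For the measured compounds named here, with no evidence for a direction, no shift beyond the scatter is expected, and the only guide is the closeness of compound 1 at 145000 nM to compound 2 at 242000 nM. The expected step is a 1.1-fold higher number from compound 1 to compound 3 (0.04 log units; within the scatter). For compound 3 the estimate is 160000 nM, with an expected range of 80000 nM to 320000 nM.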

Compound 3, half-maximal inhibitory concentration: 179000 nM
Estimate against measurement, compound 3: 1.1-fold (0.05 log units) below; low and high end bracket the measured number.
By their numbers in this assay, from the lowest: compounds 1, 3 and 2 (each within the scatter of the next).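

Compound 3 gives the series its first comparison in one place: on a carbonyl carbon whose other neighbour is a saturated chain carbon, ((methoxycarbonyl)methyl)amino in place of 2-(methoxycarbonyl)pyrrolidin-1-yl gives a 1.2-fold higher number from compound 1 to compound 3 (0.09 log units; within the scatter) in this assay. The five-membered ring and the defined stereocentre can therefore be lost, and the amide hydrogen gained, without a shift beyond the scatter in this assay. Nothing available explains this result.

On these data alone, whether a carboxylic acid in place of the methyl ester, or a longer chain between the amide nitrogen and the ester, would move the number beyond the scatter remains open. As far as these compounds go, it is also open whether this change would behave the same way on a core carrying another group, as the present comparison rests on a single pair.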